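A few compounds are considered here, and "the series" means these few. Any claim that something is new, unique, unknown or untested is made for them only; others in the source may bear on it.

Series notes.

Measured in a functional assay on DU-145 cells (Homo sapiens) for cytotoxicity, read by XTT assay, with a stated time of 72 h; on this read-out higher numbers stand for weaker inhibition and lower numbers for stronger inhibition:
compound 1 `NC(=[Se])N/N=C/c1ccc(Cl)cc1` gives 8630 nM
compound 2 `COc1ccc(/C=N/NC(N)=[Se])cc1` gives 30300 nM
compound 3 `CC(=O)N(/N=C/c1ccc(Cl)cc1)c1nc(C)c[se]1` gives 60600 nM

Compounds 1 and 2 share one core and differ in a single place, namely (methoxy in place of chloro on an aromatic carbon). In this assay that change produced a 3.5-fold higher number from compound 1 to compound 2 (0.55 log units; beyond the scatter). Compound 3 rests on a different core; the difference between the two cores is not broken down here. In this assay the number for compound 3 stands higher than that for compound 1, while compound 3 and compound 2 lie within the usual scatter of each other and no order is drawn between them.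

Compound 4 `COc1ccc(/C=N/N(C(C)=O)c2nc(C)c[se]2)cc1` is not yet measured. It differs from compound 3 by methoxy in place of chloro on an aromatic carbon. Among the compounds with values here, this is the same kind of change as the one from compound 1 to compound 2, not the same change: in compound 1 the group sits para to a group of 6 heavy atoms, in compound 3 para to a large group, and the surrounding core is different. The expectation for compound 4 in this assay therefore rests on one earlier step only, taken on another core. Compound 4 is expected to give about 150000 nM, with an expected range from 50000 nM to 450000 nM. The expected step of a 2.5-fold higher number from compound 3 to compound 4 (0.39 log units; beyond the scatter) is set beside the earlier 3.5-fold higher number from compound 1 to compound 2 (0.55 log units; beyond the scatter), with a wide range because compound 3 already stands at 60600 nM and the expectation rests on a single step from another core.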

Compound 4, half-maximal inhibitory concentration: > 74300 nM
Compound 4 gave a limit, no number (the forecaster's own chance of this, stated with the estimate: 35%); the middle value lies beyond the limit too.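

In this assay compound 4 gives > 74300 nM, which is a limit of the assay and not a number. On the second core, methoxy in place of chloro on an aromatic carbon gives an at least 1.2-fold higher number from compound 3 to compound 4 (0.08 log units; that floor lies within the scatter), so the result does not run against the direction seen on the first core, but its floor alone does not confirm that direction. The result therefore shows neither that the step carries over at the same size nor that its size depends on the core: the same change on two cores in this assay, a 3.5-fold higher number (0.55 log units; beyond the scatter) from compound 1 to compound 2 and an at least 1.2-fold higher number (0.08 log units; that floor lies within the scatter) from compound 3 to compound 4; the limit leaves it open whether they differ

From the compounds shown here alone, with one pair on each core and only chloro and methoxy at this place, the true size of the step on the second core stays open: the limit of > 74300 nM in this assay, at which 1 of the 4 values shown sits. Also open, going by these compounds, is whether a hydroxyl, an amine or a carboxylic acid in place of chloro would move the numbers in the same direction on both cores.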